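The compounds below may be only part of what the source reports. "The series", "measured", "known", "first", "only" and "open" are said of these compounds alone.

Measured so far:
Compound 1 (`O=C(CCCCCCC(=O)Nc1ccc(C(F)(F)F)cc1)NO`) gives 450 nM
Compound 2 (`O=C(CCCCCCC(=O)Nc1ccccc1Br)NO`) gives 6800 nM

In a functional assay on U-937 cells (Homo sapiens) for antiproliferative activity, with a stated time of 48 h (a higher number here means that more compound is needed for the effect, a lower number that less compound is needed), compound 1 stands lowest of the two, at 450 nM against a number for compound 2 of 6800 nM, a gap well beyond the scatter. The next compound to be tested is compound 3 (`CN(C)c1ccc(NC(=O)CCCCCCC(=O)NO)cc1`), which keeps the core of compound 1 and carries dimethylamino in place of trifluoromethyl on an aromatic carbon, para to a large group (dimethylamino in place of trifluoromethyl on an aromatic carbon). For the measured compounds named here, no measured pair differs in just one place, so the data give no direct guide to the size of this step. Compound 1 already holds the lower number at 450 nM in this small set, so a modest rise in this assay seems more likely than a fall, though it may not clear the scatter by much. The expected move is a 2.0-fold higher number from compound 1 to compound 3 (0.30 log units; within the scatter) and remains an estimate. For compound 3 the estimated value is 900 nM with an expected range from 280 nM to 3000 nM in this assay.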

Compound 3, half-maximal effective concentration: 1700 nM
Beside the measured number, compound 3's estimate is 1.9-fold (0.28 log units) below it; low and high end bracket the measured number.
By their numbers in this assay, from the lowest: compound 1; then compound 3; then compound 2.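

In this assay, this exchange gives the set its first comparison in which only one place differs: with dimethylamino in place of trifluoromethyl on an aromatic carbon, para to a large group, there is a 3.8-fold higher number from compound 1 to compound 3 (0.58 log units; beyond the scatter). The shift is modest but beyond the scatter, so what this position carries does register in these cells, and of this pair the trifluoromethyl compound holds the lower number, with 1 hydrogen-bond acceptor entering in dimethylamino where trifluoromethyl has 0. No measurement bearing on why the number moves accompanies this result.

A single step at this position cannot show whether other groups, such as a methyl, a plain amine, a methoxy or a carboxylic acid, would fall nearer to compound 1 or to compound 3, or whether any would go lower than compound 1. For the compounds shown here, it also remains open whether the same exchange would give a step of similar size on a shorter or longer chain than the one these compounds share.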